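A few compounds are considered here, and "the series" means these few. Any claim that something is new, unique, unknown or untested is made for them only; others in the source may bear on it.

Series notes. Of the compounds shown here, three have been measured and one is pending. Compound 1 `CCN(CC)C(=S)SCc1cc(=O)c2ccc(Cl)cc2o1` carries a diethylamino group on the thiocarbonyl carbon together with a chloro on the core; in a functional assay on LM7 cells (Homo sapiens) for antiproliferative activity, read by MTT assay, with a stated time of 72 h (a lower number here means a stronger inhibitor, a higher number a weaker inhibitor), compound 1 gives 8800 nM. Compound 2 `O=c1cc(CSC(=S)N2CCCC2)oc2cc(Cl)ccc12` has pyrrolidin-1-yl in place of diethylamino on the thiocarbonyl carbon. In this assay compound 2 reaches only a limit of the assay, > 25000 nM. Compound 3 `CC(C)N(C(=S)SCc1cc(=O)c2ccccc2o1)C(C)C` bears diisopropylamino on the thiocarbonyl carbon and lacks the chloro. In this assay compound 3 also sits at a limit of the assay, > 25000 nM, so no number is known for it. Two of the three values shown are the limit of > 25000 nM in this assay, at which 2 of the 3 values shown sit, and only compound 1 gives a number. Going by the values given here, the single step with one change, an at least 2.8-fold higher number from compound 1 to compound 2 (0.45 log units; beyond the scatter), concerns the amine on the thiocarbonyl carbon, not the ring.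

Compound 4 `CC(C)N(C(=S)SCc1cc(=O)c2ccc(Cl)cc2o1)C(C)C` differs from compound 3 by chloro in place of hydrogen on an aromatic carbon. Among the compounds with values here, no measured pair differs in the chloro alone, so no step bears directly on this change. Compound 1 holds a chloro with a different amine and gives 8800 nM, which leaves a number rather than a limit possible, but the diisopropylamino group of compound 3 has no measured partner. Compound 4 is therefore expected near 15000 nM, in a range from 5000 nM to 40000 nM, with a fair chance that only a limit is again reported. The expected step of an at least 1.6-fold lower number from compound 3 to compound 4 (0.22 log units; that floor lies within the scatter) is thus towards a lower number, but remains uncertain.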

Compound 4, half-maximal inhibitory concentration: > 30000 nM
Compound 4 gave a limit, no number; the forecaster's own chance of this, stated with the estimate: 50%; at least 2.0-fold (0.30 log units) between middle value and limit.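

In this assay compound 4 gives only a limit, > 30000 nM, and not a number. Chloro in place of hydrogen on the aromatic carbon therefore yields no readable effect in the diisopropylamino pair, and the steps that reach compound 4 from compound 3 and from compound 2 cannot be read, each joining two limits. With the chloro kept, diisopropylamino in place of diethylamino gives an at least 3.4-fold higher number from compound 1 to compound 4 (0.53 log units; beyond the scatter), which stands alongside pyrrolidin-1-yl in place of diethylamino at an at least 2.8-fold higher number from compound 1 to compound 2 (0.45 log units; beyond the scatter), so both amine changes shown on the chloro core lead away from the one number in the series, and the diethylamino group alone gives a number among the shown compounds.

Going by these compounds alone, whether the chloro on its own changes anything remains open, and no pair differing only in that group gives two numbers. Also open, on these data alone, is how a dimethylamino or morpholine group on the thiocarbonyl carbon, or a fluoro in place of the chloro, would read against compound 1.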